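Series notes: methoxy for bromo on the aromatic ring

The source may report more compounds than this note shows. Statements on the series, on what has been measured and on what is new or still open speak of the compounds shown alone.

In an assay with Cystic fibrosis transmembrane conductance regulator (Rattus norvegicus) as the target (a lower number here means tighter binding, a higher number weaker binding), compound 2 `OCc1cc(-c2ccccc2OCc2ccc(Br)cc2)no1` gives 147000 nM. It stands second highest of the three numbers: nearest is compound 1 `ClCc1cc(-c2ccccc2OCc2ccc(Br)cc2)no1` with 220000 nM, where a 1.5-fold lower number from compound 1 to compound 2 (0.18 log units; within the scatter); furthest is compound 3 `OCCc1cc(-c2ccccc2OCc2ccc(Br)cc2)no1` with 23000 nM, where a 6.4-fold lower number from compound 2 to compound 3 (0.81 log units; beyond the scatter) and, counted from compound 1, a 9.6-fold lower number from compound 1 to compound 3 (0.98 log units; beyond the scatter). Compound 4 `COc1ccc(COc2ccccc2-c2cc(CO)on2)cc1` differs from compound 2 by methoxy in place of bromo on an aromatic carbon. For the measured compounds named here, all three measured steps alter the group on the saturated chain carbon bound to the aromatic carbon; none alters the aromatic carbon carrying the bromo, so no measured step bears directly on this change. The expected step in this assay is therefore a 1.0-fold higher number from compound 2 to compound 4 (0.01 log units; within the scatter), not beyond the scatter in either direction. Compound 4 is estimated at 150000 nM, with a range of 50000 nM to 450000 nM.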

Compound 4, dissociation constant: 64000 nM
Compound 4: the middle estimate sits 2.3-fold (0.37 log units) above what was measured; the measured number falls inside the stated range.
By their numbers in this assay, from the lowest: compound 3; then compound 4; then compounds 2 and 1 (each within the scatter of the next).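

In this assay, methoxy in place of bromo on the aromatic carbon para to a large group gives a 2.3-fold lower number from compound 2 to compound 4 (0.36 log units; beyond the scatter). For the compounds shown here, this position therefore responds to substitution, which the earlier steps, all made on the saturated chain carbon, could not show. No supporting data on the origin of this step are available.

Going by these compounds, whether a chloro, an amine or a carboxylic acid at this position would shift the number further remains open. Also open, on these data alone, is whether methoxy in place of bromo would give a similar step with the chain of compound 3 .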